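A Benzoyl Group Gives Way to a Carbamoyl Group

The source may report more compounds than this note shows. Statements on the series, on what has been measured and on what is new or still open speak of the compounds shown alone.

Measured in a functional assay on NALM-6 cells (Homo sapiens) for cytotoxicity, with a stated time of 72 h; a higher number here means that more compound is needed for the effect, a lower number that less compound is needed:
Compound 1 `C=C[C@@](C)(/C=C/c1ccc(O)cc1)CC/C=C/C(=O)c1ccccc1`: > 43400 nM, a limit of the assay and not a number.
Compound 2 `C=C[C@@](C)(/C=C/c1ccc(O)c(/C=C/C(=O)c2ccccc2)c1)CCC=C(C)C`: 4470 nM.

Going by the values given here, compound 2 holds the only actual number in this assay, at 4470 nM. Compound 1 offers only a limit, (the limit of > 43400 nM in this assay, at which 1 of the 2 values shown sits).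

Compound 3 `C=C[C@@](C)(/C=C/c1ccc(O)c(/C=C/C(N)=O)c1)CCC=C(C)C` has not yet been measured. Its difference from compound 2 is amino in place of phenyl on a carbonyl carbon. This is amino in place of phenyl on a carbonyl carbon, which, cut one bond further out, reads as benzoyl to carbamoyl.

Among the compounds with values here, no measured pair here shows this change, so the size of the step in this assay can only be judged. A step beyond the scatter is expected, towards needing more compound, and it is reckoned from compound 2 at 4470 nM. The assay may well report only a limit for the new compound. The estimated 4.5-fold higher number from compound 2 to compound 3 (0.65 log units; beyond the scatter) is a clear loss of cytotoxicity. For compound 3 the expected value is 20000 nM, with an estimated range of 7000 nM to 55000 nM.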

Compound 3, half-maximal effective concentration: > 43400 nM
Compound 3: a limit, no number; the forecaster's own chance of this, stated with the estimate: 45%; at least 2.1-fold (0.33 log units) between middle value and limit.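

Amino on this carbonyl carbon does not stand in for phenyl in this assay: the change from benzoyl to carbamoyl gives an at least 9.7-fold higher number from compound 2 to compound 3 (0.98 log units; beyond the scatter). Going by these compounds alone, this is the first reading at this position, and it shows that the cytotoxic effect of compound 2 does not survive when the phenyl is replaced by amino, even with the rest of the structure unchanged. Compound 3 gives > 43400 nM, which is a limit of the assay and not a number, so the step has a lower bound but no measured size, and the loss may be much larger than the bound: the limit of > 43400 nM in this assay, at which 2 of the 3 values shown sit.

With only this one replacement on the carbonyl carbon, the compounds shown leave open whether the loss comes from removing the phenyl ring or from bringing in the nitrogen. A phenylamino group in this place would keep the ring while adding the nitrogen, and a methyl group would remove the ring without adding nitrogen, so these two would separate the two parts of the change.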